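The source may report more compounds than this note shows. Statements on the series, on what has been measured and on what is new or still open speak of the compounds shown alone.

Compound 1 `CC(C)C[C@H](N)c1cc(C(F)(F)F)ccc1N1CCN(C(=O)COc2ccc(O)cc2)CC1`: 4600 nM
Compound 2 `CC(C)C[C@H](N)c1cc(C(F)(F)F)ccc1N1CCN(C(=O)CC(C)C(=O)c2ccc(Cl)cc2)CC1`: 1100 nM
Compound 3 `CC(C)C[C@H](N)c1cc(C(F)(F)F)ccc1N1CCN(C(=O)COc2cccc3ccccc23)CC1`: 2600 nM

These three compounds share one core and differ only in the group on a saturated chain carbon bound to a carbonyl carbon. In an assay on HEK293 cells for displacement of a labelled ligand from Melanocortin receptor 4 (Homo sapiens) (on this read-out higher numbers stand for weaker inhibition and lower numbers for stronger inhibition), compound 1 gives 4600 nM, the highest of the three numbers. Compound 4 `CC(C)C[C@H](N)c1cc(C(F)(F)F)ccc1N1CCN(C(=O)CCC(N)=O)CC1` changes compound 1 by carbamoylmethyl in place of 4-hydroxyphenoxy on a saturated chain carbon bound to a carbonyl carbon. Two measured steps start from the same point: a 4.2-fold lower number from compound 1 to compound 2 (0.62 log units; beyond the scatter) and a 1.8-fold lower number from compound 1 to compound 3 (0.25 log units; within the scatter). Both swapped the 4-hydroxyphenoxy group for another group carrying an aromatic ring; neither tried a group without a ring, so they give no direct guide for compound 4. The number for compound 4 is expected to stay close to that of compound 1, a 1.3-fold higher number from compound 1 to compound 4 (0.12 log units; within the scatter), estimated at 6000 nM within a range from 2000 nM to 20000 nM.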

Compound 4, inhibition constant: > 10000 nM
Compound 4: only a limit was reported; the forecaster's own chance of this, stated with the estimate: 25%; middle value at least 1.6-fold (0.22 log units) away from the limit.
By their numbers in this assay, from the lowest: compound 2; then compounds 3 and 1 (each within the scatter of the next). At a limit, above all of these: compound 4.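

Compound 4 stands at a limit of the assay, not at a number: the limit of > 10000 nM in this assay, at which 1 of the 4 values shown sits. Carbamoylmethyl, the first group here without a ring, gives an at least 2.1-fold higher number from compound 1 to compound 4 (0.33 log units; beyond the scatter), an at least 3.8-fold higher number from compound 3 to compound 4 (0.58 log units; beyond the scatter) and an at least 9.0-fold higher number from compound 2 to compound 4 (0.95 log units; beyond the scatter). All three groups carrying an aromatic ring therefore give lower numbers than this ring-free group, a contrast that so far rests on compound 4 alone. As far as these compounds go, whether the weaker binding follows from the missing ring, the smaller group or the carbamoyl itself stays open, since all three changed together. A plain butyl chain or a cyclohexyl ring at this place would help to separate them.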